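Shortening the side chain on a dihydrofolate reductase inhibitor

This account rests on a few compounds, and the source may have more. Where it says the series, first, only, none or still open, it means among the compounds named here.

Measured compounds:
- compound 1 `CC1=Nc2c(O)nc(N)nc2OC1`, which in an assay on isolated protein for inhibition of Dihydrofolate reductase (Homo sapiens), read by spectrophotometry (on this read-out lower numbers stand for stronger inhibition and higher numbers for weaker inhibition), gives 242000 nM
- compound 2 `Nc1nc(O)c2c(n1)OCC(CCCc1ccccc1)=N2`, which in this assay gives 7000 nM

Of the two numbers, compound 2 holds the lower one, and the gap to compound 1 lies well beyond the usual scatter, so compound 2 is clearly the stronger inhibitor here. Compound 3 `CCCCCC1=Nc2c(O)nc(N)nc2OC1` has not yet been measured. It differs from compound 2 in one place: ethyl in place of phenyl on a saturated chain carbon, three bonds along the chain from a carbon with a double bond to nitrogen. For the measured compounds named here, no step of this kind has been measured on this core, so the outcome is uncertain. The expected step is a 2.9-fold higher number from compound 2 to compound 3 (0.46 log units; beyond the scatter), a modest shift toward weaker inhibition, of a size that may only just exceed the scatter. Compound 3 is estimated at 20000 nM, with a range from 6000 nM to 70000 nM.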

Compound 3, half-maximal inhibitory concentration: 11000 nM
Compound 3: middle estimate off by 1.8-fold (0.26 log units), on the high side; low and high end bracket the measured number.
By their numbers in this assay, from the lowest: compounds 2 and 3 (each within the scatter of the next); then compound 1.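

Putting ethyl in place of phenyl on a saturated chain carbon, three bonds along the chain from a carbon with a double bond to nitrogen, gives a 1.6-fold higher number from compound 2 to compound 3 (0.20 log units; within the scatter) and so shows that the aromatic ring is not needed to reach a number like that of compound 2. A plain carbon chain is enough: butyl in place of hydrogen on a saturated chain carbon bound to a carbon with a double bond to nitrogen gives a 22-fold lower number from compound 1 to compound 3 (1.34 log units; beyond the scatter) and is a large step. No supporting measurement explains the size of either step.

Still open, as far as these compounds go, is how a chain shorter than butyl or a longer chain such as octyl would compare with compound 3. An amine or a carboxylic acid on this chain is also untested in the compounds shown.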